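The source may hold more compounds than are shown below. What is called first, only, known or untested is meant among the compounds shown, and "the series" means these compounds.

In a functional assay on PC-3 cells (Homo sapiens) for antiproliferative activity, read by MTT assay, with a stated time of 48 h (a lower number here means a stronger inhibitor, a higher number a weaker inhibitor), compound 2 (`Cc1cc(Br)c2nc(-c3nnc(-c4ccccc4)o3)cn2c1`) gives 17800 nM as the lower of the two numbers in the series. Compound 3 (`Cc1cc(Br)c2nc(-c3nnc(-c4ccc(Cl)cc4)o3)cn2c1`) gives 42000 nM as the higher of those two numbers. Compound 1 (`Brc1ccc(-c2nnc(-c3cn4ccccc4n3)o2)cc1`) reads > 50000 nM in this measurement, which is a limit and not a number. Compound 4 (`Cc1cc(Br)c2nc(-c3nnc(-c4ccc(Br)cc4)o3)cn2c1`) differs from compound 3 by bromo in place of chloro on an aromatic carbon with bromo in place of chloro on an aromatic carbon, para to a large group. Within the data shown here, the one measured step bearing on this is a 2.4-fold higher number from compound 2 to compound 3 (0.37 log units; beyond the scatter) in which chloro took the place of hydrogen; it is modest and beyond the scatter. Among the measured compounds shown here, no measured step exchanges chloro for bromo, so compound 4 is expected to stay close to compound 3 at 42000 nM in this assay with no step beyond the scatter in either direction. The expected step is a 1.2-fold lower number from compound 3 to compound 4 (0.08 log units; within the scatter) on this estimate. For compound 4 the estimated value is 35000 nM with an expected range from 17000 nM to 50000 nM in the same read-out.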

Compound 4, half-maximal inhibitory concentration: 24500 nM
Estimate against measurement, compound 4: 1.4-fold (0.15 log units) above; low and high end bracket the measured number.
By their numbers in this assay, from the lowest: compounds 2, 4 and 3 (each within the scatter of the next, the first and the last beyond it). At a limit, above all of these: compound 1.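

On the aromatic carbon para to a large group, in this assay, exchanging chloro for bromo gives a 1.7-fold lower number from compound 3 to compound 4 (0.23 log units; within the scatter), so the 4-chlorophenyl and 4-bromophenyl compounds cannot be told apart. Bromo in place of hydrogen gives a 1.4-fold higher number from compound 2 to compound 4 (0.14 log units; within the scatter), whereas chloro in place of hydrogen gives a 2.4-fold higher number from compound 2 to compound 3 (0.37 log units; beyond the scatter), so the only step beyond the scatter at this position is now a single modest one and does not extend to both halogens. Nothing measured here gives a reason for these steps.

Still open, going by these compounds, is whether a group other than a halogen at this position, such as an amine, a methoxy group or a carboxylic acid, would bring the number clearly under that of compound 2, at 17800 nM. The steps shown also leave open whether the same exchanges would read alike on a different core.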